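Trifluoromethyl in place of bromo on compound 2's core

The source may report more compounds than this note shows. Statements on the series, on what has been measured and on what is new or still open speak of the compounds shown alone.

Of the compounds shown here, two have numbers so far. Compound 1 `O=C1NC(=O)c2c(NCc3ccccc3[N+](=O)[O-])cccc21` gives 17% in an assay for inhibition of Tryptophan 2,3-dioxygenase (Homo sapiens), with stated times of 10 min and 60 min, tested at 10 uM; a higher number here means a stronger effect of the compound at the concentration tested, a lower number a weaker effect. Compound 2 `O=[N+]([O-])c1cccc(CNc2cc(Br)cc3[nH]ncc23)c1` gives 91% in this assay, the highest of the two numbers; its nearest neighbour, compound 1, lies lower by a gap beyond the scatter. Within the data shown here, the two cores differ in several places at once, so no single step between measured compounds can be read from them.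

Compound 3 `O=[N+]([O-])c1cccc(CNc2cc(C(F)(F)F)cc3[nH]ncc23)c1` is not yet measured. It differs from compound 2 in one place: trifluoromethyl in place of bromo on an aromatic carbon. Among the measured compounds shown here, no measured pair shows this change, so there is no step to lean on. Because compound 2 already gives 91%, a change that keeps the rest of the structure intact is expected to leave the read-out near that level, and the expected step from compound 2 to compound 3 in this assay is a number 9 percentage points lower from compound 2 to compound 3 (within the scatter), that is none beyond the scatter or a small loss. Compound 3 is therefore estimated at 82%, with a range from 55% to 97%.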

Compound 3, a percentage reported as inhibition, at one concentration (the size of the read-out at that concentration, not a potency): 60%
Beside the measured number, compound 3's estimate is 22 percentage points above it; the range from low to high includes it.
By their numbers in this assay, from the lowest: compound 1; then compound 3; then compound 2.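

Bromo and trifluoromethyl on this aromatic carbon are not interchangeable: this assay gives the series its first single-place step, a number 31 percentage points lower from compound 2 to compound 3 (beyond the scatter), so the read-out depends on the group at this position. The change does not remove the effect altogether, as compound 3 still gives 60%; neither group carries a ring, a net charge, a hydrogen-bond donor or a hydrogen-bond acceptor, so the step comes with a swap of heavy atoms and none of these other counted differences. No measurement of a property of either group bears on this step, and the result itself does not tell what lies behind it.

Among these compounds, with only two groups at this carbon, it remains open whether chloro, fluoro, methyl, a nitrile or plain hydrogen would stay near compound 2 or fall nearer compound 3, so no trend can yet be drawn across groups at this position. Also open, from the compounds shown here alone, is whether a step of this size would hold with an amine or a carboxylic acid in place of the nitro group elsewhere in the structure.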